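The compounds below may be only part of what the source reports. "The series", "measured", "known", "first", "only" and "open" are said of these compounds alone.

Within the data shown here, in a functional assay on MCF7 cells (Homo sapiens) for antiproliferative activity, read by MTT assay, with a stated time of 48 h (on this read-out lower numbers stand for stronger inhibition and higher numbers for weaker inhibition), compound 1 `C#Cc1cccc(Nc2ncnc3cc(NC(=O)/C=C/c4ccccc4)sc23)c1` gives 75600 nM, the higher of the two numbers so far and thus the weaker inhibition. Compound 2 `O=C(/C=C/c1ccccc1)Nc1cc2c(Nc3ccc(F)c(Cl)c3)ncnc2s1` gives 14300 nM, a lower number by a margin beyond the scatter. Next in line is compound 3 `N#Cc1cccc(Nc2ncnc3cc(NC(=O)/C=C/c4ccccc4)sc23)c1`, with cyano in place of ethynyl on an aromatic carbon, meta to a large group (cyano in place of ethynyl on an aromatic carbon). The swap reads as 3-ethynylphenyl to 3-cyanophenyl. Among the measured compounds shown here, no measured pair yet differs in one place only, so the data offer no direct guide to this change. The working expectation in this assay is therefore no step beyond the scatter, and the estimated step is a 1.5-fold lower number from compound 1 to compound 3 (0.18 log units; within the scatter). For compound 3 the estimated value is 50000 nM, with an expected range of 17000 nM to 120000 nM.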

Compound 3, half-maximal inhibitory concentration: > 100000 nM
Compound 3 was reported as a limit; the forecaster's own chance of this, stated with the estimate: 15%; at least 2.0-fold (0.30 log units) between middle value and limit.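

In this assay, among these compounds, cyano in place of ethynyl on an aromatic carbon gives the first comparison at this position that differs in one place only, with an at least 1.3-fold higher number from compound 1 to compound 3 (0.12 log units; that floor lies within the scatter). Compound 3 stands at > 100000 nM, which is a limit of the assay and not a number: the limit of > 100000 nM in this assay, at which 1 of the 3 values shown sits. Cyano therefore brings no lower number than ethynyl at this position, but because the floor of the step lies within the scatter, a real loss is not established.

Going by these compounds, how far compound 3 lies past its limit stays unknown, and with it the true size of the step. Also open, on these data alone, is how a methoxy group or an amine, meta to a large group on this ring, would read in this assay.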